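A Trifluoromethyl Swap on a Low-Toxicity Series

A few compounds are considered here, and "the series" means these few. Any claim that something is new, unique, unknown or untested is made for them only; others in the source may bear on it.

Compound 1 `Cc1ccc(-c2nn(-c3ccccc3)cc2-c2nc3ccccc3n2S(=O)(=O)c2ccc(C(F)(F)F)cc2)cc1`: 89300 nM
Compound 2 `COc1ccc(S(=O)(=O)n2c(-c3cn(-c4ccccc4)nc3-c3ccc(F)cc3)nc3ccccc32)cc1`: 105000 nM
Compound 3 `O=S(=O)(c1ccc(F)cc1)n1c(-c2cn(-c3ccccc3)nc2-c2ccc(F)cc2)nc2ccccc21`: 174000 nM

In an ADME assay on cells (Hepatocyte, Mus musculus) for cytotoxicity, read by MTT assay, with a stated time of 24 h (on this read-out higher numbers stand for lower toxicity in this test and lower numbers for higher toxicity in this test), compound 3 gives 174000 nM, within the scatter of both other compounds. Compound 4 `O=S(=O)(c1ccc(C(F)(F)F)cc1)n1c(-c2cn(-c3ccccc3)nc2-c2ccc(F)cc2)nc2ccccc21` has trifluoromethyl in place of fluoro on an aromatic carbon, para to a large group: trifluoromethyl in place of fluoro on an aromatic carbon. Within the data shown here, the one measured step that bears on this change, a 1.7-fold higher number from compound 2 to compound 3 (0.22 log units; within the scatter), swaps methoxy for fluoro and stays within the scatter. Compound 1 also carries trifluoromethyl, though it differs elsewhere, and it gives 89300 nM. No step beyond the scatter is therefore expected, and the estimated change is a 1.4-fold lower number from compound 3 to compound 4 (0.14 log units; within the scatter). Compound 4 is expected at 125000 nM, with an estimated range from 70000 nM to 210000 nM.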

Compound 4, half-maximal cytotoxic concentration: 55300 nM
For compound 4 the middle estimate is 2.3-fold (0.35 log units) above the measured one; measured number below the stated range.
By their numbers in this assay, from the lowest: compounds 4, 1, 2 and 3 (each within the scatter of the next, the first and the last beyond it).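

At the position on an aromatic carbon para to a large group, the change from 4-fluorophenyl to 4-(trifluoromethyl)phenyl gives a step beyond the scatter in this assay (a 3.1-fold lower number from compound 3 to compound 4 (0.50 log units; beyond the scatter)), the only such step among those shown. Trifluoromethyl in place of methoxy at the same position stays within the scatter (a 1.9-fold lower number from compound 2 to compound 4 (0.28 log units; within the scatter)), as does fluoro in place of methyl at another place (a 1.6-fold lower number from compound 1 to compound 4 (0.21 log units; within the scatter)). No measured evidence here accounts for the trifluoromethyl step.

The compounds shown leave open how chloro, a nitrile or an amine at this position would read, and whether the step from fluoro to trifluoromethyl recurs with methyl in place of the compound 4 fluoro.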